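Adding a Chloro Group to Compound 1

A few compounds are considered here, and "the series" means these few. Any claim that something is new, unique, unknown or untested is made for them only; others in the source may bear on it.

Compound 1 `Cn1nc(Cc2ccccc2)c2ccccc2c1=O` was tested in a functional assay on aorta with Alpha-1D adrenergic receptor (Rattus norvegicus) as the target; a higher number here means that more compound is needed for the effect, a lower number that less compound is needed. Compound 1 gives <= 10000 nM, which is a limit of the measurement rather than a number, namely (the limit of <= 10000 nM in this assay, at which 1 of the 3 values shown sits). Two related compounds set the scale: compound 2 `CCn1nc(Cc2ccc(OC)c(OC)c2)c2ccccc2c1=O` gives 5300 nM, and compound 3 `COc1ccc(Cc2nn(C(C)(C)C)c(=O)c3ccccc23)cc1OC` gives 10000 nM. Going by the values given here, the single change between those two, a 1.9-fold higher number from compound 2 to compound 3 (0.28 log units; within the scatter), stays within the scatter. Compound 4 `Cn1nc(Cc2ccccc2Cl)c2ccccc2c1=O` is not yet measured. It differs from compound 1 by chloro in place of hydrogen on an aromatic carbon. Among the compounds with values here, no measured step touches this kind of change, so the sole comparison available, tert-butyl for ethyl, gives only a general sense that small changes to this core have moved the number little. Compound 4 is therefore estimated at 7000 nM, with a range from 2500 nM to 15000 nM, a number expected to mean a step that the limit leaves unreadable from compound 1 to compound 4.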

Compound 4, half-maximal effective concentration: 1400 nM
Beside the measured number, compound 4's estimate is 5.0-fold (0.70 log units) above it; the measured number lies below the stated range.
By their numbers in this assay, from the lowest: compound 4; then compounds 2 and 3 (each within the scatter of the next).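

The size of the step between compound 1 and compound 4 cannot be read, because compound 1 has only a limit: the limit of <= 10000 nM in this assay, at which 1 of the 4 values shown sits.

On these data alone, how far chloro in place of hydrogen moves the number in this assay remains open.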